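A few compounds are considered here, and "the series" means these few. Any claim that something is new, unique, unknown or untested is made for them only; others in the source may bear on it.

In an ADME assay on microsomes from liver (Rattus norvegicus) for metabolic stability, with a stated time of 60 min (a higher number here means that more of the compound is left, a lower number that less of the compound is left), compound 1 (`O=C(O)c1cc(-c2cccc(COc3ccc4c(c3)CN(c3ccccc3)C4=O)c2)ccc1Cl`) gives 100% with phenyl on the amide-type nitrogen in a ring. Compound 2 (`O=C(O)c1cc(-c2cccc(COc3ccc4c(c3)CN(C3CCC3)C4=O)c2)ccc1Cl`) carries cyclobutyl at that place and gives 76% as the lower of the two numbers. Within the data shown here, the next compound, compound 3 (`CC(C)CCN1Cc2cc(OCc3cccc(-c4ccc(Cl)c(C(=O)O)c4)c3)ccc2C1=O`), keeps the shared core and changes only this group (isopentyl in place of cyclobutyl on an amide-type nitrogen in a ring), so isopentyl stands in place of cyclobutyl and the four-membered ring is gone. Among the measured compounds shown here, only one measured step bears on this change: cyclobutyl in place of phenyl at the same place (a number 24 percentage points lower from compound 1 to compound 2 (beyond the scatter)). For the measured compounds named here, that was a different swap, so it shows only that changing this group can move the number by a modest amount. No open chain has been measured here yet, which makes any forecast loose. A downward step smaller than that earlier one is expected, although no real change remains possible. The estimated change is a number 14 percentage points lower from compound 2 to compound 3 (beyond the scatter) for now. For compound 3 the expected value is 62% within an estimated range of 38% to 85% in this test.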

Compound 3, percent of the compound remaining: 21%
Compound 3: the middle estimate sits 41 percentage points above what was measured, and the stated range ends above it.
By their numbers in this assay, from the lowest: compound 3; then compound 2; then compound 1.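

In this assay, among these compounds, the group on the amide-type nitrogen has a much larger influence than the first pair of compounds could show: replacing the ring with the open isopentyl chain gives a number 55 percentage points lower from compound 2 to compound 3 (beyond the scatter), a far larger drop than the one seen between phenyl and cyclobutyl. The comparison with the aromatic group is larger still, with a number 79 percentage points lower from compound 1 to compound 3 (beyond the scatter), so this single place can carry the read-out from nearly all of the compound left to much less of it while the shared core stays the same. Among these three compounds, the two groups with a ring both leave more compound than the open chain, but no measurement here explains that difference.

On these data alone, it remains open whether the low number belongs to open chains in general or to isopentyl in particular, a question that a shorter chain such as ethyl could help to settle. Cyclopentyl, a larger carbon ring than cyclobutyl, or a chain carrying an ether oxygen, such as methoxyethyl, would show how far the number at this place depends on the ring and on a chain made of carbon alone.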